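A few compounds are considered here, and "the series" means these few. Any claim that something is new, unique, unknown or untested is made for them only; others in the source may bear on it.

Measured in a functional assay on HepG2 cells (Homo sapiens) for inhibition, read by MTT assay; a higher number here means a weaker inhibitor of growth, a lower number a stronger inhibitor of growth:
compound 1 (`COc1cc2oc(-c3cccc(NC(=O)c4ccccc4)c3)cc(=O)c2c(OC)c1OC`) – 11700 nM
compound 2 (`COc1cc2oc(-c3cccc(NC(=O)c4ccc(Cl)cc4)c3)cc(=O)c2c(OC)c1OC`) – 21300 nM
compound 3 (`COc1cc2oc(-c3cccc(NC(=O)c4ccc(F)cc4)c3)cc(=O)c2c(OC)c1OC`) – 47200 nM

Compound 3 has the highest number of the three, the weakest growth inhibition here: a 4.0-fold higher number from compound 1 to compound 3 (0.61 log units; beyond the scatter) and a 2.2-fold higher number from compound 2 to compound 3 (0.35 log units; beyond the scatter). Compound 4 (`COc1cc2oc(-c3cccc(NC(=O)c4ccc(C#N)cc4)c3)cc(=O)c2c(OC)c1OC`) puts cyano in place of fluoro on an aromatic carbon, para to a large group: cyano in place of fluoro on an aromatic carbon. All three measured steps act at this same place, and the third is a 1.8-fold higher number from compound 1 to compound 2 (0.26 log units; within the scatter). Among the compounds with values here, no cyano compound has been measured, so these steps are the only guide. Compound 3 lies above both neighbours, so a modest move toward a lower number is expected. The expected step is a 2.1-fold lower number from compound 3 to compound 4 (0.33 log units; beyond the scatter). For compound 4 the estimate is 22000 nM, with an expected range of 9000 nM to 50000 nM.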

Compound 4, concentration for 50% growth inhibition: 10200 nM
Compound 4: the middle estimate sits 2.2-fold (0.33 log units) above what was measured, and the stated range covers the measured number.
By their numbers in this assay, from the lowest: compounds 4, 1 and 2 (each within the scatter of the next, the first and the last beyond it); then compound 3.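

In this assay, within the data shown here, the group at this aromatic carbon decides the number more clearly than the earlier compounds showed: cyano in place of fluoro gives a 4.6-fold lower number from compound 3 to compound 4 (0.67 log units; beyond the scatter), and cyano in place of chloro gives a 2.1-fold lower number from compound 2 to compound 4 (0.32 log units; beyond the scatter). Cyano in place of hydrogen gives a 1.1-fold lower number from compound 1 to compound 4 (0.06 log units; within the scatter), so a group at this carbon can leave the number level with the unsubstituted benzamide. Nothing available bears on the reason for these differences.

Open, on these data alone, is whether an amine or a carboxylic acid at this carbon would stay within this span of values.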